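A few compounds are considered here, and "the series" means these few. Any claim that something is new, unique, unknown or untested is made for them only; others in the source may bear on it.

In a physicochemical assay for solubility, measured as kinetic solubility (a lower number here means a less soluble compound, a higher number a more soluble compound), compound 2 `O=C(Nc1ccnnc1)c1cc(N2CCNCC2)ccc1OCc1ccccc1` gives 98000 nM and compound 1 `O=C(Nc1ccnnc1)c1cc(N2C[C@H]3COC[C@H]3C2)ccc1OCc1ccccc1` gives 57000 nM, two values within the scatter of each other. Compound 3 `CN1CC2(CCN(c3ccc(OCc4ccccc4)c(C(=O)Nc4ccnnc4)c3)CC2)C1` changes one group of compound 2: a group of 10 heavy atoms (8 carbon, 2 nitrogen; one four-membered non-aromatic ring with 1 hetero atom, one six-membered non-aromatic ring with 1 hetero atom) in place of a group of 6 heavy atoms (4 carbon, 2 nitrogen; one six-membered non-aromatic ring with 2 hetero atoms), on an aromatic carbon. Within the data shown here, only one measured step bears on this, a 1.7-fold higher number from compound 1 to compound 2 (0.24 log units; within the scatter), which also exchanges the non-aromatic ring group on that aromatic carbon. One small step is thin evidence, but it gives no reason to expect a large shift. The expected change in this assay is therefore none beyond the scatter, an estimated 1.2-fold lower number from compound 2 to compound 3 (0.09 log units; within the scatter). For compound 3, the estimated value is 80000 nM, with an expected range of 35000 nM to 130000 nM.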

Compound 3, solubility: 266000 nM
Compound 3: middle estimate off by 3.3-fold (0.52 log units), on the low side; the whole stated range lies below it.
By their numbers in this assay, from the lowest: compounds 1 and 2 (each within the scatter of the next); then compound 3.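

On this aromatic carbon, the earlier exchange of ring groups stayed within the scatter, but in this assay the group with a four-membered and a six-membered ring moves the number clearly: a 2.7-fold higher number from compound 2 to compound 3 (0.43 log units; beyond the scatter), and a 4.7-fold higher number from compound 1 to compound 3 (0.67 log units; beyond the scatter). The position therefore responds to the choice of ring group, and the entering group has no hydrogen-bond donor, unlike piperazin-1-yl. Nothing available explains this shift. Still open, as far as these compounds go, is whether the group's size or the missing donor goes with the higher number, and how a morpholin-4-yl or open-chain dimethylamino group here would compare.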